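The compounds below may be only part of what the source reports. "The series", "measured", "known", "first", "only" and "open" are said of these compounds alone.

Three compounds share one core and differ only in the group hanging from the carbon that is double-bonded to nitrogen. Compound 1 `CCCSc1nc(N/N=C/c2ccc(Cl)cc2)c2nnn(Cc3ccccc3)c2n1` carries a 4-chlorophenyl there, compound 2 `CCCSc1nc(N/N=C/c2ccc(N(C)C)cc2)c2nnn(Cc3ccccc3)c2n1` a 4-(dimethylamino)phenyl, and compound 3 `CCCSc1nc(N/N=C/c2ccc3ccccc3c2)c2nnn(Cc3ccccc3)c2n1` a naphthalen-2-yl. In a functional assay on MCF7 cells (Homo sapiens) for antiproliferative activity, read by MTT assay, with a stated time of 72 h (a lower number here means a stronger inhibitor, a higher number a weaker inhibitor), compound 1 reaches only the limit of the measurement, > 64000 nM. Compound 3 likewise gives only a limit in this assay, > 64000 nM. Among the compounds with values here, compound 2 is the one member of the set with a proper number, giving 12200 nM in this assay. The swap an at least 5.2-fold lower number from compound 1 to compound 2 (0.71 log units; beyond the scatter) and the swap an at least 5.2-fold higher number from compound 2 to compound 3 (0.71 log units; beyond the scatter) both move the aromatic group, and both are large enough to count; a step that the two limits leave unreadable from compound 1 to compound 3 cannot be read because of the limit of > 64000 nM in this assay, at which 2 of the 3 values shown sit.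

Compound 4 `C#CCSc1nc(N/N=C/c2ccc(N(C)C)cc2)c2nnn(Cc3ccccc3)c2n1` keeps the aromatic group of compound 2 and changes the sulfanyl chain instead: ethynyl in place of ethyl on a saturated chain carbon bound to a sulfur. Within the data shown here, no measured step touches that chain, so nothing here says which way the number should move. The expectation for compound 4 in this assay is therefore a value close to that of compound 2, estimated at 12000 nM with a plausible span from 4000 nM to 40000 nM, which means an expected step of a 1.0-fold lower number from compound 2 to compound 4 (0.01 log units; within the scatter).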

Compound 4, half-maximal inhibitory concentration: > 64000 nM
Compound 4: no number, only a limit; the forecaster's own chance of this, stated with the estimate: 20%; middle value at least 5.3-fold (0.72 log units) from the limit.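

Changing the sulfanyl chain alone is enough to move the result in this assay: ethynyl in place of ethyl on a saturated chain carbon bound to a sulfur gives an at least 5.2-fold higher number from compound 2 to compound 4 (0.71 log units; beyond the scatter). Until now, only changes to the aromatic group had been seen to do this, so the propyl chain of compound 2 is now shown to count towards its measurable activity as well. The true size of the step stays hidden, as the result for compound 4 is only a limit, and the set as a whole runs up against that same ceiling: the limit of > 64000 nM in this assay, at which 3 of the 4 values shown sit.

Still open, from the compounds shown here alone, is whether the triple bond itself matters or whether other replacements for the propyl chain would also weaken compound 2. An allyl group, a butyl chain or a methyl group on the sulfur, each paired with the 4-(dimethylamino)phenyl group, would help separate these two readings.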